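A few compounds are considered here, and "the series" means these few. Any claim that something is new, unique, unknown or untested is made for them only; others in the source may bear on it.

- Compound 1 `Cn1cc(C(=O)Nc2ccc(-c3ccccc3)c(C(F)(F)F)c2)c(=O)c2ccccc21`: 1.2 10^-6 cm/s
- Compound 2 `Cn1cc(C(=O)Nc2ccc(-c3ccccn3)c(C(F)(F)F)c2)c(=O)c2ccccc21`: 11 10^-6 cm/s
- Compound 3 `Cn1cc(C(=O)Nc2ccc(-c3cccnc3)c(C(F)(F)F)c2)c(=O)c2ccccc21`: 18 10^-6 cm/s

In an ADME assay on LLC-PK1 cells (Sus scrofa) for permeability, in the apical to basolateral direction (a lower number here means that the compound crosses the layer more slowly, a higher number that the compound crosses the layer faster), compound 3 and compound 2 form the upper pair, and compound 1 sits well apart from both. Compound 4 `Cn1cc(C(=O)Nc2ccc(-c3ccncc3)c(C(F)(F)F)c2)c(=O)c2ccccc21` differs from compound 3 in one place: pyridin-4-yl in place of pyridin-3-yl on an aromatic carbon, with pyridin-4-yl in place of pyridin-3-yl on an aromatic carbon. Replacing phenyl brought clear steps, a 9.2-fold higher number from compound 1 to compound 2 (0.96 log units; beyond the scatter) and a 15-fold higher number from compound 1 to compound 3 (1.18 log units; beyond the scatter). Among the compounds with values here, the closest precedent, exchanging one pyridinyl group for another, gave only a 1.6-fold higher number from compound 2 to compound 3 (0.21 log units; within the scatter), which is within the scatter. The expected result is therefore a 1.2-fold lower number from compound 3 to compound 4 (0.08 log units; within the scatter), with no change beyond the scatter. For compound 4 the estimated value is 15 10^-6 cm/s, with an expected range of 7 10^-6 cm/s to 30 10^-6 cm/s.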

Compound 4, apparent permeability: 15 10^-6 cm/s
For compound 4 middle estimate and measured number coincide at the digits printed; low and high end bracket the measured number.
By their numbers in this assay, from the lowest: compound 1; then compounds 2, 4 and 3 (each within the scatter of the next).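

With pyridin-4-yl, all three pyridinyl groups have now been read at this position, para to a large group, in this assay. Pyridin-4-yl gives a 1.2-fold lower number from compound 3 to compound 4 (0.08 log units; within the scatter) and a 1.4-fold higher number from compound 2 to compound 4 (0.13 log units; within the scatter), so the place of the ring nitrogen does not separate these three compounds. Its step from phenyl, a 13-fold higher number from compound 1 to compound 4 (1.10 log units; beyond the scatter), matches the clear rise seen with the other two pyridinyl groups, though no measurement here explains that rise. Still open, as far as these compounds go, is how a pyrimidine ring, with two ring nitrogens, would compare. So is how an amine on the pyridine ring would compare.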